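Aryl sulfonyl variation: the chloro to fluoro step

The source may report more compounds than this note shows. Statements on the series, on what has been measured and on what is new or still open speak of the compounds shown alone.

Compound 1 `O=C(c1ccc(OCCCN2CC[C@H](NS(=O)(=O)c3cccc(Cl)c3)C2)cc1)C1CC1` carries a 3-chlorophenyl on the sulfonyl sulfur of the shared core. In an assay on isolated protein for binding affinity to histamine H2 receptor (Homo sapiens) (on this read-out higher numbers stand for weaker inhibition and lower numbers for stronger inhibition), compound 1 gives 700 nM. Among the three measured compounds this is the second highest number; its nearest neighbour is compound 3 `Cc1ccc(S(=O)(=O)N[C@H]2CCN(CCCOc3ccc(C(=O)C4CC4)cc3)C2)cc1`, which in this assay gives 380 nM, a step of a 1.8-fold lower number from compound 1 to compound 3 (0.27 log units; within the scatter). The furthest is compound 2 `N#Cc1ccc(S(=O)(=O)N[C@H]2CCN(CCCOc3ccc(C(=O)C4CC4)cc3)C2)cc1`, which gives 1600 nM, the step being a 2.3-fold higher number from compound 1 to compound 2 (0.36 log units; beyond the scatter). Between the two aryl replacements themselves the step is a 4.2-fold lower number from compound 2 to compound 3 (0.62 log units; beyond the scatter).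

Compound 4 `O=C(c1ccc(OCCCN2CC[C@H](NS(=O)(=O)c3cccc(F)c3)C2)cc1)C1CC1` differs from compound 1 in one place: fluoro in place of chloro on an aromatic carbon. Within the data shown here, no measured step exchanges one halogen for another, so the bearing steps are only those replacing the chloro altogether: the methyl step stays within the scatter, the cyano step reaches just beyond it. A change confined to a single halogen atom at the same place is therefore expected to give no step beyond the scatter, with a slight lean toward a higher number.

The expected step is a 1.3-fold higher number from compound 1 to compound 4 (0.11 log units; within the scatter). For compound 4 the estimate in this assay is 900 nM, in the range 400 nM to 2000 nM.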

Compound 4, inhibition constant: 1600 nM
For compound 4 the middle estimate is 1.8-fold (0.25 log units) below the measured one; measured number inside the range.
By their numbers in this assay, from the lowest: compounds 3 and 1 (each within the scatter of the next); then compounds 2 and 4 (each within the scatter of the next).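

In this assay the exchange of one halogen for another at this position is not neutral: the step is a 2.3-fold higher number from compound 1 to compound 4 (0.36 log units; beyond the scatter), as large as the step that replaces the chloro with a different aryl pattern, a 2.3-fold higher number from compound 1 to compound 2 (0.36 log units; beyond the scatter). Measured against the other aryl groups, the step is a 4.2-fold higher number from compound 3 to compound 4 (0.62 log units; beyond the scatter) on one side and no change at the digits printed from compound 2 to compound 4 (within the scatter) on the other, so the 3-fluorophenyl group falls with the 4-cyanophenyl group, apart from the pair of compound 1 and compound 3, and a single heavy atom exchanged on an aromatic carbon, with no change in the counted donors, acceptors or charge, is enough to separate compound 1 from compound 4. Nothing available on these compounds bears on the origin of this step.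

Still open, as far as these compounds go, is where bromo, methoxy or an amino group on the same aromatic carbon, meta to a large group, would stand relative to chloro and fluoro. Also open, from the compounds shown here alone, is whether fluoro in place of chloro gives a step of this size when the shared core carries a longer chain.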